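The source may hold more compounds than are shown below. What is called first, only, known or untested is meant among the compounds shown, and "the series" means these compounds.

Three analogues sharing one core have been measured in an ADME assay on L6 cells (Rattus norvegicus) for cytotoxicity, read by resazurin assay, with a stated time of 72 h; on this read-out lower numbers stand for stronger inhibition and higher numbers for weaker inhibition. Compound 1 `CN(C)C12CC(c3ccccc3)C(CN(C(=O)CN3CCCCC3)C1)C(c1ccccc1)C2` gives 12100 nM, and compound 2 `CN(C)C12CC(c3ccccc3)C(CN(C(=O)CN3CCCC3)C1)C(c1ccccc1)C2` gives 12600 nM. Compound 3 `CN(C)C12CC(c3ccccc3)C(CN(CCCN3CCCC3)C1)C(c1ccccc1)C2` gives 1550 nM, the lowest of the three numbers. The step of a 7.8-fold lower number from compound 1 to compound 3 (0.89 log units; beyond the scatter) and the step of an 8.1-fold lower number from compound 2 to compound 3 (0.91 log units; beyond the scatter) both lie beyond the scatter; the two cores differ as follows: 3-(pyrrolidin-1-yl)propyl in place of ((pyrrolidin-1-yl)methyl)carbonyl on an amine nitrogen in a ring. Between compound 2 and compound 1 the change is piperidin-1-yl in place of pyrrolidin-1-yl on a saturated chain carbon bound to a carbonyl carbon, and the step it made, a 1.0-fold lower number from compound 2 to compound 1 (0.02 log units; within the scatter), is within the scatter.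

Compound 4 `CN(C)C12CC(c3ccccc3)C(CN(CCCN3CCCCC3)C1)C(c1ccccc1)C2` remains to be measured in this assay. It differs from compound 3 by piperidin-1-yl in place of pyrrolidin-1-yl on a saturated chain carbon, three bonds along the chain from an amine nitrogen in a ring, the same kind of change as that from compound 2 to compound 1, though the place is not the same: there the ring sits on a saturated chain carbon bound to a carbonyl carbon, here on a saturated chain carbon, three bonds along the chain from an amine nitrogen in a ring. Because the earlier step of a 1.0-fold lower number from compound 2 to compound 1 (0.02 log units; within the scatter) stayed within the scatter, a step of similar size is expected here. Compound 4 is expected to give 1500 nM, somewhere between 750 nM and 3000 nM. Compound 4 is thus expected to show a step of a 1.0-fold lower number from compound 3 to compound 4 (0.01 log units; within the scatter).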

Compound 4, half-maximal inhibitory concentration: 1750 nM
Compound 4: middle estimate off by 1.2-fold (0.07 log units), on the low side; the measured number falls inside the stated range.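

With piperidin-1-yl in place of pyrrolidin-1-yl, the step in this assay is a 1.1-fold higher number from compound 3 to compound 4 (0.05 log units; within the scatter), and the same exchange reads alike on the two cores: the same change on two cores in this assay, a 1.0-fold lower number (0.02 log units; within the scatter) from compound 2 to compound 1 and a 1.1-fold higher number (0.05 log units; within the scatter) from compound 3 to compound 4, 1.2-fold (0.07 log units) apart, within the scatter of two such steps

The larger steps in this set come with the other side chain, a 7.2-fold lower number from compound 2 to compound 4 (0.86 log units; beyond the scatter) and a 6.9-fold lower number from compound 1 to compound 4 (0.84 log units; beyond the scatter), so 3-(piperidin-1-yl)propyl stands apart from the carbonyl-bearing side chain much as 3-(pyrrolidin-1-yl)propyl does. Among these compounds, this shows only that the ring exchange made no step beyond the scatter on either of these two cores; it does not show that the exchange would stay this small on any other core, and two pairs give no general rule for the series.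

The compounds shown leave open how a morpholine ring or an open-chain amine such as dimethylamino would read at the end of the propyl chain. They also leave open what a shorter or longer chain would do to the number.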